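A few compounds are considered here, and "the series" means these few. Any claim that something is new, unique, unknown or untested is made for them only; others in the source may bear on it.

Measured in a functional assay on HepG2 cells (Homo sapiens) for antiproliferative activity, read by MTT assay, with a stated time of 24 h; a higher number here means a weaker inhibitor, a lower number a stronger inhibitor:
- Compound 1 `Cc1ccc(-c2nn(-c3ccccc3)cc2-c2nc3ccccc3n2S(=O)(=O)c2ccccc2)cc1`: 960 nM
- Compound 2 `Cc1ccc(-c2nn(-c3ccccc3)cc2-c2nc3ccccc3n2S(=O)(=O)c2ccc(Cl)cc2)cc1`: 5520 nM

Compound 1 holds the lower of these two numbers. Compound 3 `O=S(=O)(c1ccccc1)n1c(-c2cn(-c3ccccc3)nc2-c2ccc(C(F)(F)F)cc2)nc2ccccc21` is next, with trifluoromethyl in place of methyl on an aromatic carbon, para to a large group. Within the data shown here, the only measured step, a 5.8-fold higher number from compound 1 to compound 2 (0.76 log units; beyond the scatter), is a different substitution, chloro in place of hydrogen, and so gives only loose guidance. A modest rise in this assay is expected, with the direction uncertain. The estimated change is a 2.1-fold higher number from compound 1 to compound 3 (0.32 log units; beyond the scatter). For compound 3 the expected value is 2000 nM, with an estimated range of 500 nM to 8000 nM.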

Compound 3, half-maximal inhibitory concentration: 590 nM
Estimate against measurement, compound 3: 3.4-fold (0.53 log units) above; measured number inside the range.
By their numbers in this assay, from the lowest: compounds 3 and 1 (each within the scatter of the next); then compound 2.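

In this assay, going from 4-methylphenyl to 4-(trifluoromethyl)phenyl gives a 1.6-fold lower number from compound 1 to compound 3 (0.21 log units; within the scatter) and so leaves the number unchanged within the scatter. This place on the core of compound 1 therefore accepts trifluoromethyl in place of methyl, whereas the earlier chloro step was beyond the scatter. No supporting data explain this result.

Open, from the compounds shown here alone, is whether a methoxy group or an amine at this place would also hold the number. Also open, going by these compounds, is whether trifluoromethyl would behave the same way alongside the chloro substituent of compound 2.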